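This account rests on a few compounds, and the source may have more. Where it says the series, first, only, none or still open, it means among the compounds named here.

Measured compounds:
Compound 1, `CCCCCCCC/C=C/CCCCCCCC(=O)Nc1c(OC)cc(OC)cc1OC`, in an assay on microsomes from intestine with acyl-CoA:cholesterol acyltransferase (Oryctolagus cuniculus) as the target (on this read-out higher numbers stand for weaker inhibition and lower numbers for stronger inhibition), gives 51 nM.
Compound 2, `CCCCCCCCCCC(C)C(=O)Nc1c(OC)cc(OC)cc1OC`, in this assay gives 90 nM.

Going by the values given here, of these two numbers, the one for compound 2 is the higher, but its nearest neighbour, compound 1, stands within the usual scatter of it, so the two values show no separation that can be read as a difference in inhibition.

Compound 3, `CCCCCCCCCCC(CC)C(=O)Nc1c(OC)cc(OC)cc1OC`, is not yet measured. It differs from compound 2 by methyl in place of hydrogen on a saturated chain carbon, two bonds along the chain from a carbonyl carbon. Among the compounds with values here, no step between measured compounds of this kind is available, so the expectation rests only on the two numbers in hand, which lie close together. Compound 3 is expected to stay close to compound 2, with a step of a 1.1-fold higher number from compound 2 to compound 3 (0.05 log units; within the scatter) that is not expected to go beyond the scatter in either direction. Compound 3 is therefore estimated at 100 nM, within a range from 40 nM to 260 nM.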

Compound 3, half-maximal inhibitory concentration: 73 nM
Beside the measured number, compound 3's estimate is 1.4-fold (0.14 log units) above it; the range from low to high includes it.
By their numbers in this assay, from the lowest: compounds 1, 3 and 2 (each within the scatter of the next).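

Going by these compounds alone, compound 3 gives the first reading of a change at this position, on a saturated chain carbon, two bonds along the chain from a carbonyl carbon. In this assay, methyl to ethyl there gives a 1.2-fold lower number from compound 2 to compound 3 (0.09 log units; within the scatter) and so leaves inhibition without a separable difference: at this position, the one added carbon is accommodated with no loss that the assay can resolve. No evidence is at hand that bears on this result.

Going by these compounds, one step at one position cannot show a trend, so whether a longer chain such as propyl or butyl at this place would also stay within the scatter remains open. Also open, on these data alone, is how a hydroxyl, an amine or a carboxylic acid there would read, and how the unbranched chain, with hydrogen in place of the methyl of compound 2, would compare.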